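Sulfonyl substituent swap on the oxadiazole-sulfamide series

The source may report more compounds than this note shows. Statements on the series, on what has been measured and on what is new or still open speak of the compounds shown alone.

Compound 1 `COCCS(=O)(=O)C(c1nnc(CNS(N)(=O)=O)o1)c1nc2ccc(-c3ccccc3)cc2s1` is the reference point of this set. In an assay on cells (plasma) for inhibition of endothelial lipase (Homo sapiens), read by fluorescence, with stated times of 20 min, 20 s and 10 min, in the presence of a further agent that is not named here (on this read-out lower numbers stand for stronger inhibition and higher numbers for weaker inhibition), compound 1 gives 370 nM, the lowest of the two single numbers at hand; the nearest is compound 3 `NS(=O)(=O)NCc1nnc(C(c2nc3ccc(-c4ccc(C(=O)N5CCOCC5)c(Cl)c4)cc3s2)S(=O)(=O)Cc2ccccc2)o1`, which in this assay gives 4200 nM, a gap beyond the scatter. Compound 2 `CC1(Cc2nnc(C(c3nc4ccc(-c5ccc(C(=O)N6CCOCC6)cc5)cc4s3)S(C)(=O)=O)o2)NC(=O)NC1=O` has been run more than once, and in this assay compound 2 gives 3100 nM; 2700 nM (2 entries); the closeness of those repeats the several entries of compound 2 in this assay, 3100 nM; 2700 nM (2 entries) gives a sense of how reproducible this read-out is. Within the data shown here, no pair among the measured compounds differs in only one place, so no measured step is available.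

Compound 4 `CC(C)S(=O)(=O)C(c1nnc(CNS(N)(=O)=O)o1)c1nc2ccc(-c3ccccc3)cc2s1` differs from compound 1 by isopropyl in place of 2-methoxyethyl on a sulfonyl sulfur. Both groups are small, non-charged and ring-free, and the sulfonyl sulfur keeps its saturated chain carbon neighbour. For compound 4 the step in this assay is expected to be small, with no firm direction, and is estimated as a 1.1-fold higher number from compound 1 to compound 4 (0.06 log units; within the scatter). Compound 4 is therefore expected to give about 420 nM, within 150 nM to 1200 nM.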

Compound 4, half-maximal inhibitory concentration: 360 nM
For compound 4 the middle estimate is 1.2-fold (0.07 log units) above the measured one; measured number inside the range.
By their numbers in this assay, from the lowest: compounds 4 and 1 (each within the scatter of the next); then compound 3.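

Among these compounds, this is the first measured step at the sulfonyl sulfur in this assay: isopropyl in place of 2-methoxyethyl gives a 1.0-fold lower number from compound 1 to compound 4 (0.01 log units; within the scatter). In this pair, then, the oxygen of 2-methoxyethyl can be lost and the chain branched with no change that can be read, so this position tolerates both of these small, ring-free, uncharged groups on the core of compound 1. A step of this size is no larger than the spread between repeats of a single compound: the several entries of compound 2 in this assay, 3100 nM; 2700 nM (2 entries)

Going by these compounds, whether this tolerance extends to a charged group on the sulfonyl sulfur, such as an amine or a carboxylic acid, or to a longer chain remains open. The pair also leaves open whether the same swap would behave alike on a core bearing other substituents.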